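Replacing a hydroxy group with a ring-bearing amine

The source may hold more compounds than are shown below. What is called first, only, known or untested is meant among the compounds shown, and "the series" means these compounds.

Three compounds share one core and differ only in the group on one aromatic carbon. Compound 1 `Cc1cc(C2CCCCC2)c(S(C)(=O)=O)cc1C(=O)N=C(N)N` carries a cyclohexyl group there and in a functional assay for inhibition of sodium/hydrogen exchanger (Oryctolagus cuniculus) (a higher number here means a weaker inhibitor, a lower number a stronger inhibitor), compound 1 gives 22 nM. Compound 2 `Cc1cc(-c2ccccc2)c(S(C)(=O)=O)cc1C(=O)N=C(N)N` carries a phenyl group, and compound 2 gives 19 nM; a 1.2-fold lower number from compound 1 to compound 2 (0.06 log units; within the scatter). Compound 3 `Cc1cc(O)c(S(C)(=O)=O)cc1C(=O)N=C(N)N` carries a hydroxy group, and compound 3 gives 220 nM, the highest of the three numbers, so it is the weakest inhibitor shown.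

Compound 4 `Cc1cc(N2CCC(N)CC2)c(S(C)(=O)=O)cc1C(=O)N=C(N)N` is compound 3 with one change: 4-aminopiperidin-1-yl in place of hydroxy on an aromatic carbon.

Going by the values given here, two measured steps bear on this. Both replace the hydroxy group by a ring: a 10-fold higher number from compound 1 to compound 3 (1.00 log units; beyond the scatter) and a 12-fold higher number from compound 2 to compound 3 (1.06 log units; beyond the scatter). Read in the other direction, putting a ring in place of hydroxy lowered the number beyond the scatter in both cases. The entering 4-aminopiperidin-1-yl also contains a ring, though with two nitrogen atoms, so the exact size of the effect is uncertain. A downward step, beyond the scatter, is expected.

Compound 4 is therefore estimated at 40 nM, with a range from 10 nM to 160 nM; the expected step is a 5.5-fold lower number from compound 3 to compound 4 (0.74 log units; beyond the scatter).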

Compound 4, half-maximal inhibitory concentration: 9.8 nM
Beside the measured number, compound 4's estimate is 4.1-fold (0.61 log units) above it, and the stated range ends above it.
By their numbers in this assay, from the lowest: compounds 4, 2 and 1 (each within the scatter of the next, the first and the last beyond it); then compound 3.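

Until now, only carbon rings had been seen at this position, and compound 4 shows that a ring holding nitrogen and carrying an amino group also gives a far lower number than hydroxy in this assay (a 22-fold lower number from compound 3 to compound 4 (1.35 log units; beyond the scatter)). The new group also compares well with the carbon rings: a 1.9-fold lower number from compound 2 to compound 4 (0.29 log units; within the scatter) leaves compound 4 level with the phenyl compound, while a 2.2-fold lower number from compound 1 to compound 4 (0.35 log units; beyond the scatter) puts it modestly ahead of the cyclohexyl compound. So at this position, a ring carbon is not needed at the point of attachment, and the ring can carry an amino group without any loss against these carbon rings; no measurement shown here accounts for this result.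

The compounds shown cannot separate what the piperidine ring contributes from what its amino group contributes, and plain piperidin-1-yl, with no amino group, would be the direct comparison with compound 4. From the compounds shown here alone, it also remains open how an open-chain amine such as dimethylamino, or a ring carrying a carboxylic acid in place of the amino group, would compare at this position.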